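Compound 3: 2-methoxyphenyl in place of 4-chlorophenyl

The source may hold more compounds than are shown below. What is called first, only, known or untested is meant among the compounds shown, and "the series" means these compounds.

Measured in a functional assay on SK-OV-3 cells (Homo sapiens) for antiproliferative activity, read by MTT assay, with a stated time of 24 h (a higher number here means a weaker inhibitor, a lower number a stronger inhibitor), so far:
- compound 1 `COc1cccc(/C=C/C(=O)c2ccc(OC)c3c2OC(C)(C)C=C3)c1` gives 9360 nM as a number
- compound 2 `COc1ccc(C(=O)/C=C/c2ccc(Cl)cc2)c2c1C=CC(C)(C)O2` gives > 10000 nM as a limit of the assay

Compound 2 therefore stands at a limit and has no number. Compound 3 `COc1ccccc1/C=C/C(=O)c1ccc(OC)c2c1OC(C)(C)C=C2` is still to be measured and differs from compound 2 in one place: 2-methoxyphenyl in place of 4-chlorophenyl on a double-bonded chain carbon bound to a double-bonded chain carbon. Among the compounds with values here, the only measured step at that place is an at least 1.0-fold higher number from compound 1 to compound 2 (0.02 log units; that floor lies within the scatter), where 4-chlorophenyl replaces 3-methoxyphenyl. Within the data shown here, compound 1 carries 3-methoxyphenyl there and gives 9360 nM as the one number available. With 2-methoxyphenyl entering, no step beyond the scatter is expected in this assay, and no direction can be assigned. The expected change is an at least 1.1-fold lower number from compound 2 to compound 3 (0.04 log units; that floor lies within the scatter) and is no more than a working estimate. For compound 3 the estimate is 9000 nM, with an expected range of 3500 nM to 20000 nM and a real chance of another limit.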

Compound 3, half-maximal inhibitory concentration: > 10000 nM
Compound 3 ended at the assay's limit (the forecaster's own chance of this, stated with the estimate: 40%); at least 1.1-fold (0.04 log units) between middle value and limit.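

In this assay compound 3 gives > 10000 nM, which is a limit of the assay and not a number. Moving the methoxy group from 3-methoxyphenyl to 2-methoxyphenyl gives an at least 1.0-fold higher number from compound 1 to compound 3 (0.02 log units; that floor lies within the scatter), so this change at the double-bonded chain carbon shows only a floor within the scatter, and the step between the two compounds at the limit cannot be read. With 2-methoxyphenyl added, the limit now dominates the small set of results at this position: the limit of > 10000 nM in this assay, at which 2 of the 3 values shown sit.

Going by these compounds, the true size of the change from 3-methoxyphenyl to 2-methoxyphenyl, and any order between compound 2 and compound 3, remain open. On these data alone, it is also open whether a phenyl ring carrying an amine or a carboxylic acid at this place would give a number clearly lower than that of compound 1 at 9360 nM.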